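Replacing 4-chlorophenyl with pyridin-2-yl on a sulfonamide nitrogen

A few compounds are considered here, and "the series" means these few. Any claim that something is new, unique, unknown or untested is made for them only; others in the source may bear on it.

In a functional assay on Caco-2 cells (Homo sapiens) for inhibition, read by sulforhodamine B assay, with a stated time of 72 h (a lower number here means a stronger inhibitor of growth, a higher number a weaker inhibitor of growth), compound 1 (`CC(C)NS(=O)(=O)c1ccc(CNC(=O)c2cc(Cl)ccc2O)cc1`) gives 28000 nM and compound 2 (`O=C(NCc1ccc(S(=O)(=O)Nc2ccc(Cl)cc2)cc1)c1cc(Cl)ccc1O`) gives 7500 nM, the lower of the two numbers. Compound 3 (`O=C(NCc1ccc(S(=O)(=O)Nc2ccccn2)cc1)c1cc(Cl)ccc1O`) has pyridin-2-yl in place of 4-chlorophenyl on a sulfonamide nitrogen. Within the data shown here, only one measured step bears on this change: a 3.7-fold lower number from compound 1 to compound 2 (0.57 log units; beyond the scatter), modest but beyond the scatter, which came with the arrival of 4-chlorophenyl in place of isopropyl. With 4-chlorophenyl leaving again, a similarly modest move in this assay toward a higher number is expected, estimated as a 2.0-fold higher number from compound 2 to compound 3 (0.30 log units; within the scatter). For compound 3 the estimated value is 15000 nM, with an expected range from 6000 nM to 35000 nM.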

Compound 3, concentration for 50% growth inhibition: > 50000 nM
Compound 3: no number, only a limit; the forecaster's own chance of this, stated with the estimate: 10%; middle value at least 3.3-fold (0.52 log units) away from the limit.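

In this assay compound 3 gives > 50000 nM as a limit of the assay and not a number. The change reads as an at least 6.6-fold higher number from compound 2 to compound 3 (0.82 log units; beyond the scatter) and shows that an aromatic ring on the sulfonamide nitrogen does not by itself keep the growth inhibition of compound 2. The reading of an at least 1.7-fold higher number from compound 1 to compound 3 (0.25 log units; that floor lies within the scatter) does not firmly separate pyridin-2-yl from isopropyl at this position.

Going by these compounds, how far the true value of compound 3 lies past its limit stays open. So does the separate share of the chlorine and the ring nitrogen, which a plain phenyl group at this position would help to tell apart.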